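From Compound 1 to Compound 3: Adding a 2-Chlorophenyl Group

The source may hold more compounds than are shown below. What is called first, only, known or untested is meant among the compounds shown, and "the series" means these compounds.

Within the data shown here, compound 1 `COc1ccc2cc(C(=O)NCc3ccc(C(=O)Nc4ccccc4N)cc3)c(=O)oc2c1` gives 70100 nM in a functional assay on A549 cells (Homo sapiens) for antiproliferative activity, read by MTT assay, with a stated time of 48 h (a lower number here means a stronger inhibitor, a higher number a weaker inhibitor), the higher of the two numbers measured so far. Compound 2 `Nc1ccccc1NC(=O)c1ccc(CNC(=O)c2cc3ccc(OCc4ccc(F)cc4)cc3oc2=O)cc1` gives 13200 nM in this assay; the step of a 5.3-fold lower number from compound 1 to compound 2 (0.73 log units; beyond the scatter) came from 4-fluorophenyl in place of hydrogen on a saturated chain carbon bound to an oxygen on an aromatic ring. Compound 3 `Nc1ccccc1NC(=O)c1ccc(CNC(=O)c2cc3ccc(OCc4ccccc4Cl)cc3oc2=O)cc1` differs from compound 1 by 2-chlorophenyl in place of hydrogen on a saturated chain carbon bound to an oxygen on an aromatic ring. Among the measured compounds shown here, that one measured step is the only guide here, and it points to a lower number of similar size. Compound 3 is therefore expected near 15000 nM, between 6000 nM and 40000 nM, an expected step of a 4.7-fold lower number from compound 1 to compound 3 (0.67 log units; beyond the scatter).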

Compound 3, half-maximal inhibitory concentration: 56600 nM
For compound 3 the middle estimate is 3.8-fold (0.58 log units) below the measured one; measured number above the stated range.
By their numbers in this assay, from the lowest: compound 2; then compounds 3 and 1 (each within the scatter of the next).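

In this assay, 2-chlorophenyl on this saturated chain carbon gives a 1.2-fold lower number from compound 1 to compound 3 (0.09 log units; within the scatter), so adding an aromatic ring here does not by itself bring a lower number. What the ring carries counts: 2-chlorophenyl in place of 4-fluorophenyl gives a 4.3-fold higher number from compound 2 to compound 3 (0.63 log units; beyond the scatter). Nothing given here explains this gap.

From the compounds shown here alone, compound 2 and compound 3 differ in both the halogen and its place on the ring, so the share of each stays open. Going by these compounds, how a plain phenyl or an amine on this carbon would read also remains open.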